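Ester Chain Swap on a Thiophene-Bearing Dihydropyrimidinone

A few compounds are considered here, and "the series" means these few. Any claim that something is new, unique, unknown or untested is made for them only; others in the source may bear on it.

Compound 1 `CC1=C(C(=O)OCC2CCC2)C(c2ccco2)NC(=O)N1`: 42%
Compound 2 `CCC(C)OC(=O)C1=C(C)NC(=O)NC1c1cccs1`: 5%

Of the compounds shown here, two have been measured in an assay on membranes from CHO cells for displacement of a labelled ligand from adenosine receptor A1 (Homo sapiens), read by scintillation counting, with a stated time of 60 min, tested at 1 uM; a lower number here means less inhibition, a higher number more inhibition at the concentration tested (going by the name of the read-out). In this assay compound 1 gives 42%, while compound 2 gives 5%. Compound 2 thus stands lowest of the two numbers, and the gap to compound 1 is beyond the scatter. Among the measured compounds shown here, the two compounds differ in more than one place, so their values alone are known, and no single step is recorded between them.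

Compound 3 `CC1=C(C(=O)OCC2CCC2)C(c2cccs2)NC(=O)N1` has not yet been measured in this assay. It differs from compound 2 as follows: cyclobutylmethyl in place of sec-butyl on an oxygen next to a carbonyl group. The ester side chain of compound 3 is the same as that of compound 1, although the two still differ elsewhere. Since compound 1 carries this chain and gives 42%, an upward step from compound 2 is expected. The step this estimate means, a number 23 percentage points higher from compound 2 to compound 3 (beyond the scatter), is expected to be upward and beyond the scatter. Compound 3 is therefore estimated to give 28% in this assay, with a range from 5% to 50%.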

Compound 3, a percentage reported as inhibition, at one concentration (the size of the read-out at that concentration, not a potency): 39%
Compound 3: the middle estimate sits 11 percentage points below what was measured, within the range that was stated.
By their numbers in this assay, from the lowest: compound 2; then compounds 3 and 1 (each within the scatter of the next).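

In this assay, cyclobutylmethyl in place of sec-butyl on an oxygen next to a carbonyl group gives a number 34 percentage points higher from compound 2 to compound 3 (beyond the scatter). Among the compounds shown here, this is the first single change recorded, and it shows that the low reading of compound 2 goes with its sec-butyl chain, since the rest of the structure stays the same in this step. The second step, thiophen-2-yl in place of furan-2-yl on a saturated ring carbon, gives a number 3 percentage points lower from compound 1 to compound 3 (within the scatter), so with cyclobutylmethyl on the ester the two rings cannot be told apart in this assay.

The compounds shown do not separate the four-membered ring of cyclobutylmethyl from the size of the chain, so how a straight pentyl chain or a cyclopropylmethyl group would read on the same oxygen remains open. From the compounds shown here alone, it also remains open whether furan-2-yl and thiophen-2-yl would still match with sec-butyl on the ester, and how a phenyl ring would read on the saturated ring carbon. No measurement given here accounts for the size of the ester step.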